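Aryl replacements on the shared core: outlook for compound 4

The compounds below may be only part of what the source reports. "The series", "measured", "known", "first", "only" and "open" are said of these compounds alone.

The series shares the core of compound 1 `Nc1ncnn2c([C@@H]3O[C@H](CO)[C@@H](O)[C@H]3O)cc(C#Cc3cccs3)c12` and varies the group on one aromatic carbon of it. In a functional assay on LN-229 cells (Homo sapiens) for antiproliferative activity, with a stated time of 72 h (a higher number here means a weaker inhibitor, a lower number a stronger inhibitor), compound 1 gives only the limit > 100000 nM, so what is known of it is the limit of > 100000 nM in this assay, at which 1 of the 3 values shown sits. Compound 2 `Nc1ncnn2c([C@@H]3O[C@H](CO)[C@@H](O)[C@H]3O)cc(C#Cc3ccccc3)c12` gives 88000 nM in this assay, and compound 3 `Nc1ncnn2c([C@@H]3O[C@H](CO)[C@@H](O)[C@H]3O)cc(-c3ccccc3)c12` gives 75100 nM. The steps of an at least 1.1-fold lower number from compound 1 to compound 2 (0.05 log units; that floor lies within the scatter), an at least 1.3-fold lower number from compound 1 to compound 3 (0.12 log units; that floor lies within the scatter) and a 1.2-fold lower number from compound 2 to compound 3 (0.07 log units; within the scatter) all stay within the scatter, so the three measured compounds cannot be ranked against one another.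

Compound 4 `Nc1ncnn2c([C@@H]3O[C@H](CO)[C@@H](O)[C@H]3O)cc(-c3ccccc3F)c12` has not been measured. Its change from compound 1 is 2-fluorophenyl in place of 2-(thiophen-2-yl)ethynyl on an aromatic carbon. The closest measured step is an at least 1.3-fold lower number from compound 1 to compound 3 (0.12 log units; that floor lies within the scatter), in which phenyl entered at the same place without moving beyond the scatter. For the measured compounds named here, with 2-fluorophenyl rather than phenyl entering, no measured step exists, so no change beyond the scatter is expected in this assay, and the expected step is an at least 1.1-fold lower number from compound 1 to compound 4 (0.07 log units; that floor lies within the scatter). Compound 4 is therefore estimated at 85000 nM, with a range from 40000 nM to 200000 nM, and a sizeable chance that only a limit is reported.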

Compound 4, half-maximal inhibitory concentration: > 100000 nM
Compound 4: a limit, no number; the forecaster's own chance of this, stated with the estimate: 35%; middle value at least 1.1-fold (0.07 log units) away from the limit.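

In this assay compound 4 gives only a limit, > 100000 nM, the same limit as compound 1, so the step between those two cannot be read. On these data alone, the readable steps are an at least 1.3-fold higher number from compound 3 to compound 4 (0.12 log units; that floor lies within the scatter) and an at least 1.1-fold higher number from compound 2 to compound 4 (0.05 log units; that floor lies within the scatter); each floor lies within the scatter, so 2-fluorophenyl on this aromatic carbon is not set apart from phenyl or 2-phenylethynyl, and the true size of each step stays unknown. A limit now appears both with a group on a triple bond and with an aryl ring attached directly: the limit of > 100000 nM in this assay, at which 2 of the 4 values shown sit.

As far as these compounds go, the size of any effect of fluoro in place of hydrogen remains open. Also open is whether an amine, a carboxylic acid or a longer chain on this aromatic carbon would give a value clearly beyond the scatter of those shown.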